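Aryl replacement on the piperazine nitrogen of compound 1

The source may hold more compounds than are shown below. What is called first, only, known or untested is meant among the compounds shown, and "the series" means these compounds.

Measured so far:
compound 1 `Nc1ccccc1NC(=O)c1ccc(CSC(=S)N2CCN(Cc3ccccn3)CC2)cc1` — 65.2%
compound 2 `CN(C(=S)SCc1ccc(C(=O)Nc2ccccc2N)cc1)c1cccnc1` — 82.5%
compound 3 `CC1CCCCN1C(=S)SCc1ccc(C(=O)Nc2ccccc2N)cc1` — 86.9%

In a functional assay on MGC-803 cells (Homo sapiens) for antiproliferative activity, read by CCK-8 assay, with a stated time of 72 h, tested at 8 uM (a higher number here means a stronger effect of the compound at the concentration tested, a lower number a weaker effect), compound 1 gives the lowest of the three numbers. Compound 2 stands above it in this assay, with a gap beyond the scatter, and compound 3 stands further above it, again beyond the scatter. Within the data shown here, the only change between two measured compounds is a number 4.4 percentage points higher from compound 2 to compound 3 (within the scatter), which sits on the thiocarbonyl carbon and not on the piperazine.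

Compound 4 `N#Cc1ccc(N2CCN(C(=S)SCc3ccc(C(=O)Nc4ccccc4N)cc3)CC2)cc1` is unmeasured. It differs from compound 1 as 4-cyanophenyl in place of (pyridin-2-yl)methyl on an amine nitrogen in a ring. Among the measured compounds shown here, no measured step touches this position, so there is nothing to carry over directly; the one step known, on the thiocarbonyl carbon, stayed within the scatter, and it says nothing about the ring nitrogen. The expectation therefore rests on compound 1 alone as the starting point, with the higher numbers of compound 2 and compound 3 marking how far the series has reached.

For compound 4 the expected step is a number 6.8 percentage points higher from compound 1 to compound 4 (within the scatter), no clear direction beyond the scatter. Compound 4 is estimated at 72%, within 55% to 88%.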

Compound 4, a percentage reported as inhibition, at one concentration (the size of the read-out at that concentration, not a potency): 37.6%
Beside the measured number, compound 4's estimate is 34.4 percentage points above it, outside the stated range (below it).
By their numbers in this assay, from the lowest: compound 4; then compound 1; then compounds 2 and 3 (each within the scatter of the next).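

In this assay, among these compounds, 4-cyanophenyl in place of (pyridin-2-yl)methyl on the amine nitrogen in the ring gives a number 27.6 percentage points lower from compound 1 to compound 4 (beyond the scatter), so this position responds to substitution, and this is the only step between compounds differing in one place that lies beyond the scatter. The change is not a single-feature swap: the entering group has a six-membered aromatic ring of carbon only and a triple bond outside aromatic rings, while the leaving group has a ring with one hetero atom and a methyl link to the ring nitrogen, so the step cannot be assigned to any one of these features. No measurement at hand accounts for the drop.

Still open, on these data alone, is whether the lower number follows the nitrile, the loss of the ring hetero atom in the pyridine, or the loss of the methyl link. Plain phenyl, benzyl and 4-cyanobenzyl on the same nitrogen would separate these readings, and a pyridin-2-yl group attached directly to that nitrogen would test the link alone.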